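Thiocarbamoyl on the pyrazoline nitrogen: cytotoxicity of compound 4

This account rests on a few compounds, and the source may have more. Where it says the series, first, only, none or still open, it means among the compounds named here.

Measured so far:
compound 1, `CNC(=O)c1cc(Oc2ccc(C3=NNC(c4cccc([N+](=O)[O-])c4)C3)cc2)ccn1`: 26500 nM
compound 2, `CNC(=O)c1cc(Oc2ccc(C3CC(c4ccc([N+](=O)[O-])cc4)=NN3)cc2)ccn1`: 28900 nM
compound 3, `CNC(=O)c1cc(Oc2ccc(C3=NN(C(N)=S)C(c4cccc([N+](=O)[O-])c4)C3)cc2)ccn1`: > 50000 nM

Of the compounds shown here, three have been tested in a functional assay on HepG2 cells (Homo sapiens) for cytotoxicity, read by MTT assay, with a stated time of 72 h; on this read-out higher numbers stand for weaker inhibition and lower numbers for stronger inhibition. Compound 1 gives 26500 nM in this assay. Compound 2, which has the same atoms joined differently, gives 28900 nM in this assay, and the two numbers lie within the scatter of each other; the difference between the two cores is not broken down here. For compound 3 this assay reports only a limit, > 50000 nM, and no number; this is the limit of > 50000 nM in this assay, at which 1 of the 3 values shown sits.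

Compound 3 derives from compound 1 by a group of 3 heavy atoms (1 carbon, 1 nitrogen, 1 sulfur; no ring) in place of a hydrogen atom, on an amine nitrogen in a ring, and that change made a step of an at least 1.8-fold higher number from compound 1 to compound 3 (0.27 log units; that floor lies within the scatter).

Compound 4, `CNC(=O)c1cc(Oc2ccc(C3CC(c4ccc([N+](=O)[O-])cc4)=NN3C(N)=S)cc2)ccn1`, has not yet been measured. It derives from compound 2 by a group of 3 heavy atoms (1 carbon, 1 nitrogen, 1 sulfur; no ring) in place of a hydrogen atom, on an amine nitrogen in a ring. This is the same kind of change as from compound 1 to compound 3, though the surroundings differ: in compound 1 the site is next to the ring atom that bears a 3-nitrophenyl group and two ring bonds from the ring atom that bears a large group, while in compound 2 it is next to the ring atom that bears a large group and two ring bonds from the ring atom that bears a 4-nitrophenyl group.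

For compound 4 the expected step is a 1.7-fold higher number from compound 2 to compound 4 (0.24 log units; within the scatter) in this assay, resting on the step of an at least 1.8-fold higher number from compound 1 to compound 3 (0.27 log units; that floor lies within the scatter) and on compound 2 starting from 28900 nM. Compound 4 is therefore estimated at 50000 nM in this assay, likely between 25000 nM and 100000 nM, with a fair chance that only a limit is reported.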

Compound 4, half-maximal inhibitory concentration: > 50000 nM
Compound 4 ended at the assay's limit (the forecaster's own chance of this, stated with the estimate: 60%); the middle value sits exactly at the limit.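

On the core of compound 2, the thiocarbamoyl group in place of a hydrogen atom, on an amine nitrogen in a ring, gave a step of an at least 1.7-fold higher number from compound 2 to compound 4 (0.23 log units; that floor lies within the scatter) in this assay. Set beside the same change on the other core, this step can be compared only through its floor, and neither floor lies beyond the scatter: the same change on two cores in this assay, an at least 1.8-fold higher number (0.27 log units; that floor lies within the scatter) from compound 1 to compound 3 and an at least 1.7-fold higher number (0.23 log units; that floor lies within the scatter) from compound 2 to compound 4; the limit leaves it open whether they differ. Compound 3 and compound 4 both stand at a limit and not at a number, so the series shows that on both cores the change gave a result at that limit, but it does not show how large either step is or that the change carries over with the same size: the limit of > 50000 nM in this assay, at which 2 of the 4 values shown sit.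

The compounds shown leave open what a carbamoyl group, with oxygen in place of the sulfur, or an acetyl group on the same nitrogen would give in this assay, and whether either would yield a number rather than a limit. They also leave open how an amine or a carboxylic acid in place of the nitro group on the phenyl ring would read on either core.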